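Removing a trifluoromethyl group from compound 1

This account rests on a few compounds, and the source may have more. Where it says the series, first, only, none or still open, it means among the compounds named here.

Compound 1 `COc1cc(-c2nn(-c3cccc(NC(=O)c4cccc(C(F)(F)F)c4)c3)cc2-c2ccncc2)ccc1Cl` is measured in a functional assay on HCT-15 cells (Homo sapiens) for inhibition, read by sulforhodamine B assay, with a stated time of 48 h (a higher number here means a weaker inhibitor of growth, a lower number a stronger inhibitor of growth), where compound 1 gives 1550 nM, the highest of the three numbers shown. Compound 2 `COc1cc(-c2nn(-c3cccc(NC(=O)Nc4ccc(Cl)c(Cl)c4)c3)cc2-c2ccncc2)ccc1Cl` gives 1230 nM, and the change a 1.3-fold lower number from compound 1 to compound 2 (0.10 log units; within the scatter) lies within the scatter. For the measured compounds named here, compound 3 `O=C(Nc1cccc(-n2cc(-c3ccncc3)c(-c3ccc(Cl)c(O)c3)n2)c1)Nc1cc(C(F)(F)F)cc(C(F)(F)F)c1` gives 474 nM, a lower number that lies beyond the scatter; no single-change step links it to compound 1.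

Compound 4 `COc1cc(-c2nn(-c3cccc(NC(=O)c4ccccc4)c3)cc2-c2ccncc2)ccc1Cl` differs from compound 1 by hydrogen in place of trifluoromethyl on an aromatic carbon. Going by the values given here, the only step that touches the group on the carbonyl carbon is the one from compound 1 to compound 2, and it stayed within the scatter, so the change in this assay is expected to be small and in no sure direction. Compound 4 is therefore estimated at 2000 nM, between 900 nM and 5000 nM, a step of a 1.3-fold higher number from compound 1 to compound 4 (0.11 log units; within the scatter).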

Compound 4, concentration for 50% growth inhibition: 654 nM
Beside the measured number, compound 4's estimate is 3.1-fold (0.49 log units) above it; measured number outside the range, below it.
By their numbers in this assay, from the lowest: compounds 3, 4, 2 and 1 (each within the scatter of the next, the first and the last beyond it).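

In this assay, removing the trifluoromethyl group gives a 2.4-fold lower number from compound 1 to compound 4 (0.37 log units; beyond the scatter), the first single change shown to step beyond the scatter, so this aromatic carbon does matter and plain hydrogen serves better here than trifluoromethyl. Exchanging the group on the carbonyl carbon gives a 1.9-fold lower number from compound 2 to compound 4 (0.27 log units; within the scatter), so compound 4 and compound 2 cannot be told apart. No accompanying measurement explains the drop from trifluoromethyl to hydrogen. Still open, from the compounds shown here alone, is how an amine or a carboxylic acid on this same aromatic carbon would compare with hydrogen, and whether removing trifluoromethyl from compound 3 would act alike.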